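From 2,6-dichlorobenzyl to 3-methoxybenzyl on the sulfur

A few compounds are considered here, and "the series" means these few. Any claim that something is new, unique, unknown or untested is made for them only; others in the source may bear on it.

Among the compounds with values here, in a functional assay on PC-3 cells (Homo sapiens) for cytotoxicity, read by MTT assay (on this read-out lower numbers stand for stronger inhibition and higher numbers for weaker inhibition), compound 3 `COc1ccc2cc([C@H](C)c3nnc(SCc4c(Cl)cccc4Cl)n3-c3ccc(F)cc3)ccc2c1` gives 216000 nM, the only actual number so far. Compound 1 `COc1ccc2cc([C@H](C)c3nnc(SCc4ccc(Cl)cc4)n3-c3ccc(F)cc3)ccc2c1` reads <= 400000 nM, which is a limit and not a number. Compound 2 `COc1ccc2cc([C@H](C)c3nnc(SCc4ccc(F)cc4)n3-c3ccc(F)cc3)ccc2c1` reads <= 400000 nM, also a limit.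

Compound 4 `COc1cccc(CSc2nnc([C@@H](C)c3ccc4cc(OC)ccc4c3)n2-c2ccc(F)cc2)c1` carries 3-methoxyphenyl in place of 2,6-dichlorophenyl on a saturated chain carbon bound to a sulfur.

The measured changes closest to this one, at the same place, are a step that the limit leaves unreadable from compound 1 to compound 3 and a step that the limit leaves unreadable from compound 2 to compound 3. The remaining one, a step that the two limits leave unreadable from compound 1 to compound 2, concerns the same group. None can be sized because of the limit of <= 400000 nM in this assay, at which 2 of the 3 values shown sit. Within the data shown here, with no sized step available, no change beyond the scatter is expected in this assay, so compound 3 at 216000 nM remains the reference. A reading at the limit, as for compound 1 and compound 2, also remains possible. The expected move is a 1.2-fold higher number from compound 3 to compound 4 (0.06 log units; within the scatter). Compound 4 is estimated at 250000 nM, with an expected range of 100000 nM to 400000 nM.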

Compound 4, half-maximal inhibitory concentration: 211000 nM
The estimate for compound 4 lay 1.2-fold (0.07 log units) above the measured number; the measured number falls inside the stated range.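

In this assay, within the data shown here, the exchange of 2,6-dichlorophenyl for 3-methoxyphenyl on a saturated chain carbon bound to a sulfur gives the first step that can be sized (a 1.0-fold lower number from compound 3 to compound 4 (0.01 log units; within the scatter)). Two aromatic groups with different substituents, chlorine in one and a methoxy oxygen in the other, are therefore not told apart at this place, and this holds for this one pair only. The steps from compound 1 and from compound 2 to compound 4 cannot be read: the limit of <= 400000 nM in this assay, at which 2 of the 4 values shown sit.

From the compounds shown here alone, whether any replacement at this place moves the number beyond the scatter remains open. An amine or a carboxylic acid on the aromatic ring, or a longer chain in place of the benzyl group, would test this.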